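The source may hold more compounds than are shown below. What is called first, only, known or untested is meant among the compounds shown, and "the series" means these compounds.

Measured compounds: compound 1 `O=C(O)CCCCCC[C@@H]1[C@@H](CNS(=O)(=O)c2ccc(F)cc2)CC[C@H]1F`, 6000 nM; compound 2 `O=C(O)CCCCC[C@@H]1[C@@H](CNS(=O)(=O)c2ccc(F)cc2)CC[C@H]1F`, 4700 nM; compound 3 `O=C(O)CC/C=C\CC1=CCC[C@@H]1NS(=O)(=O)c1ccc(F)cc1`, 1300 nM.

In a functional assay on a cell-free system (plasma) for inhibition of thromboxane A2 receptor (Homo sapiens), read by turbidimetry (a higher number here means a weaker inhibitor, a lower number a stronger inhibitor), compound 2 holds the second highest of the three numbers, with compound 1 close by and compound 3 further off. Compound 4 `O=C(O)CCC/C=C\C[C@@H]1[C@@H](CNS(=O)(=O)c2ccc(F)cc2)CC[C@H]1F` differs from compound 2 in this way: 5-carboxypent-1-en-1-yl in place of 4-carboxybutyl on a saturated chain carbon bound to a saturated ring carbon. Within the data shown here, the only measured step on the shared core, a 1.3-fold lower number from compound 1 to compound 2 (0.11 log units; within the scatter), concerns chain length alone and was small. Among the measured compounds shown here, compound 3 also carries a double bond outside aromatic rings in its chain and gives the lowest number, but its core is different, so no measured step bears directly on the new double bond. Compound 4 is therefore expected to show a 1.9-fold lower number from compound 2 to compound 4 (0.27 log units; within the scatter). Compound 4 is estimated at 2500 nM, within 800 nM to 8000 nM.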

Compound 4, half-maximal inhibitory concentration: 2000 nM
The estimate for compound 4 lay 1.3-fold (0.10 log units) above the measured number; the measured number falls inside the stated range.
By their numbers in this assay, from the lowest: compounds 3 and 4 (each within the scatter of the next); then compounds 2 and 1 (each within the scatter of the next).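

On the shared core, in this assay, 5-carboxypent-1-en-1-yl in place of 4-carboxybutyl gave a 2.4-fold lower number from compound 2 to compound 4 (0.37 log units; beyond the scatter), and in place of 5-carboxypentyl it gave a 3.0-fold lower number from compound 1 to compound 4 (0.48 log units; beyond the scatter), whereas the chain-length change alone gave only a 1.3-fold lower number from compound 1 to compound 2 (0.11 log units; within the scatter). At this place, then, the unsaturated chain separates from both saturated chains, which a change of chain length alone did not do. Nothing available accounts for this result. On these data alone, whether a triple bond or the opposite double-bond geometry would give the same stays open, as does an amide in place of the carboxylic acid.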